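Alkyl on the imine nitrogen: from methyl to isopropyl

The compounds below may be only part of what the source reports. "The series", "measured", "known", "first", "only" and "open" are said of these compounds alone.

Measured in a functional assay for inhibition, with Rattus norvegicus as the target; on this read-out lower numbers stand for stronger inhibition and higher numbers for weaker inhibition:
Compound 1, `CC(C)C/N=c1\c(O)c(O)\c1=N/Cc1ccc(C#N)cc1`: 10200 nM
Compound 2, `C/N=c1\c(O)c(O)\c1=N/Cc1ccc(C#N)cc1`: > 30000 nM

Compound 2 stands at the limit of this assay, its value being a limit rather than a number, as the limit of > 30000 nM in this assay, at which 1 of the 2 values shown sits, records. Compound 3, `CC(C)/N=c1\c(O)c(O)\c1=N/Cc1ccc(C#N)cc1`, differs from compound 2 by isopropyl in place of methyl on a double-bonded nitrogen. Among the measured compounds shown here, the only measured step that bears on this change is an at least 2.9-fold higher number from compound 1 to compound 2 (0.46 log units; beyond the scatter), where removing the isopropyl from the saturated chain carbon bound to the double-bonded nitrogen weakened inhibition. Putting an isopropyl directly on that nitrogen in compound 3 restores part of the bulk lost on going to compound 2, so compound 3 is expected to show a step of an at least 2.0-fold lower number from compound 2 to compound 3 (0.30 log units; that floor lies within the scatter) toward stronger inhibition, though the limit for compound 2 makes its size uncertain. Compound 3 is estimated at 15000 nM, within 6000 nM to 40000 nM.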

Compound 3, half-maximal inhibitory concentration: 14000 nM
The estimate for compound 3 lay 1.1-fold (0.03 log units) above the measured number; the range from low to high includes it.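

In this assay, exchanging methyl for isopropyl directly on the double-bonded nitrogen gives an at least 2.1-fold lower number from compound 2 to compound 3 (0.33 log units; beyond the scatter), so this single change is now tied to stronger inhibition. The comparison with the isobutyl of compound 1 gives a 1.4-fold higher number from compound 1 to compound 3 (0.14 log units; within the scatter), so the two chains cannot be told apart at this place in this read-out. Compound 2 carries a limit and not a number, so the step from it gives only a floor for the size of the change: the limit of > 30000 nM in this assay, at which 1 of the 3 values shown sits.

The compounds shown leave open whether a longer chain such as hexyl, or a cyclohexyl ring, on this nitrogen would give stronger inhibition than isopropyl or isobutyl. They also leave open how an amine or a carboxylic acid at the end of such a chain would read in this assay.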